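A few compounds are considered here, and "the series" means these few. Any claim that something is new, unique, unknown or untested is made for them only; others in the source may bear on it.

The three urea compounds made so far share one core and differ only in the group carried on the second aromatic ring. Compound 1, with structure `Cc1cc(NC(=O)Nc2ccccc2N)c2ccccc2n1`, is the starting point here. In an ADME assay on HEK293 cells (Homo sapiens) for cytotoxicity, with a stated time of 72 h (a higher number here means that more compound is needed for the effect, a lower number that less compound is needed), compound 1 gives > 25000 nM, which is a limit of the measurement rather than a number. Compound 2, with structure `CSc1ccccc1NC(=O)Nc1cc(C)nc2ccccc12`, also gives a limit, > 25000 nM, in this assay. Compound 3, with structure `Cc1cc(NC(=O)Nc2ccccc2C(F)(F)F)c2ccccc2n1`, likewise gives only the limit > 25000 nM in this assay. Because of this, as the limit of > 25000 nM in this assay, at which 3 of the 3 values shown sit, shows, the steps from compound 1 to compound 2, a step that the two limits leave unreadable from compound 1 to compound 2, from compound 1 to compound 3, a step that the two limits leave unreadable from compound 1 to compound 3, and from compound 2 to compound 3, a step that the two limits leave unreadable from compound 2 to compound 3, cannot be read in size or direction.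

Compound 4, with structure `Cc1cc(NC(=O)Nc2cccc(Cl)c2)c2ccccc2n1`, is not yet measured. It differs from compound 1 as follows: 3-chlorophenyl in place of 2-aminophenyl on an amide-type nitrogen. Among the measured compounds shown here, no measured step directly matches this change, and the three measured steps give no readable size. For the measured compounds named here, the only guide is that every compound so far sits at the limit. Compound 4 is therefore expected to sit near the same limit, with the step from compound 1 to compound 4 estimated as a step that the limit leaves unreadable from compound 1 to compound 4. The estimate for compound 4 in this assay is 30000 nM, expected to fall between 12000 nM and 100000 nM.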

Compound 4, half-maximal effective concentration: 21000 nM
Compound 4: the middle estimate sits 1.4-fold (0.15 log units) above what was measured, and the stated range covers the measured number.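

Compound 4 is the only compound shown whose result in this assay is an actual number, 21000 nM, and not a limit, so this place on the amide-type nitrogen now has one readable value. Putting 3-chlorophenyl in place of 2-aminophenyl gives an at least 1.1-fold lower number from compound 1 to compound 4 (0.07 log units; that floor lies within the scatter), so even this first usable comparison does not establish a real difference between the two compounds. The step is only a floor, and its true size and the other steps among the compounds shown cannot be read, because compound 1 and the other two compounds carry only a limit: the limit of > 25000 nM in this assay, at which 3 of the 4 values shown sit.

The compounds shown leave open whether a number in this range belongs to the chlorine itself or to the 3-chlorophenyl group as a whole, since the change also removes the amino group. A bromine, a methoxy group or a carboxylic acid on that ring would be further cases in this assay, and nothing here tells how any of them would read.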